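From ethoxy to isobutoxy on a shared core

A few compounds are considered here, and "the series" means these few. Any claim that something is new, unique, unknown or untested is made for them only; others in the source may bear on it.

In a functional assay on the whole organism (strain Sprague-Dawley) for inhibition, with Rattus norvegicus as the target, with a stated time of 10 min (a higher number here means that more compound is needed for the effect, a lower number that less compound is needed), compound 1 (`CCOC(=O)c1cnc(-c2ccccc2N)[nH]c1=O`) stands as "not determined" (no result reported) and so offers no number to compare. Compound 2 (`CCOC(=O)c1cnc(-c2ccccc2OC)[nH]c1=O`) needs 10 mg/kg for the effect, while compound 3 (`CCOC(=O)c1cnc(-c2ccccc2OCC)[nH]c1=O`) needs 2 mg/kg and holds the lower of the two numbers. Compound 4 (`CCOC(=O)c1cnc(-c2ccccc2OCC(C)C)[nH]c1=O`) has not been measured yet. It differs from compound 3 by isopropyl in place of methyl on a saturated chain carbon bound to an oxygen on an aromatic ring, which turns ethoxy into isobutoxy. Going by the values given here, only one measured step bears on this change: methyl in place of hydrogen on the same kind of carbon gave a 5.0-fold lower number from compound 2 to compound 3 (0.70 log units; beyond the scatter) and lay beyond the scatter. A single step cannot show whether a further change to the chain keeps lowering the number, so no step beyond the scatter is expected in this assay and the range stays wide. The expected step is a 1.3-fold lower number from compound 3 to compound 4 (0.12 log units; within the scatter) and remains only an estimate. Compound 4 is expected at 1.5 mg/kg within an estimated range from 0.4 mg/kg to 7 mg/kg when it is tested.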

Compound 4, dose for 50% inhibition: 3 mg/kg
The estimate for compound 4 lay 2.0-fold (0.30 log units) below the measured number; low and high end bracket the measured number.
By their numbers in this assay, from the lowest: compounds 3 and 4 (each within the scatter of the next); then compound 2.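

In this assay, putting isopropyl in place of methyl on a saturated chain carbon bound to an oxygen on an aromatic ring gives a 1.5-fold higher number from compound 3 to compound 4 (0.18 log units; within the scatter), so the numbers for compound 3 and compound 4 cannot be told apart. The lower number reached with ethoxy is thus kept with isobutoxy but not clearly taken further, and the comparison with methoxy still shows a 3.3-fold lower number from compound 2 to compound 4 (0.52 log units; beyond the scatter). No measured evidence explains this result.

The compounds shown leave open whether a longer straight chain, such as butyl in place of the isobutyl, would also keep the number at this level. On these data alone, it also stays open whether an amine or a carboxylic acid on that same chain would keep it there or lose it.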